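From tert-butyl to methyl on a carbonyl carbon

A few compounds are considered here, and "the series" means these few. Any claim that something is new, unique, unknown or untested is made for them only; others in the source may bear on it.

Compound 1 `COc1ccc(-c2sc(NC(=O)C(C)(C)C)nc2C)cc1S(=O)(=O)NCCO` gives > 40000 nM in an ADME assay on Huh-7 cells (Homo sapiens) for cytotoxicity, with a stated time of 3 days; on this read-out lower numbers stand for higher toxicity in this test and higher numbers for lower toxicity in this test
Compound 2 `CC(=O)Nc1nc(C)c(-c2ccc(Cl)c(S(=O)(=O)Nc3ccc(O)cc3)c2)s1` gives 7000 nM in this assay

Compound 1 stands at > 40000 nM and this is a limit of the assay, not a number. Compound 2 gives 7000 nM as a measured number.

Compound 3 `COc1ccc(-c2sc(NC(C)=O)nc2C)cc1S(=O)(=O)NCCO` has not yet been measured. It has methyl in place of tert-butyl on a carbonyl carbon, so that (tert-butyl)carbonyl becomes acetyl. The counted change is methyl in place of tert-butyl on a carbonyl carbon and the rest of compound 1 stays as it is.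

No measured pair among these compounds shows what such a change does in this assay and the limit for compound 1 leaves the true starting point unknown. The expected a number no higher from compound 1 to compound 3 (the limit leaves the size open) is no shift beyond the scatter in either direction. Compound 3 is therefore expected to lie close to the limit of the assay and may be reported only as a limit itself. The estimated value for compound 3 is 40000 nM with an expected range of 18000 nM to 80000 nM for this measurement.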

Compound 3, half-maximal cytotoxic concentration: 42000 nM
Compound 3: the middle estimate sits 1.1-fold (0.02 log units) below what was measured; measured number inside the range.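

No step can be read from compound 1 to compound 3 in this assay, because the result for compound 1 is a limit of the assay and not a number: the limit of > 40000 nM in this assay, at which 1 of the 3 values shown sits.

The compounds shown leave open what methyl in place of tert-butyl on a carbonyl carbon does in this assay.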